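Aryl amine variation on the shared core: toward compound 4

The source may hold more compounds than are shown below. What is called first, only, known or untested is meant among the compounds shown, and "the series" means these compounds.

In a functional assay on MGC-803 cells (Homo sapiens) for cytotoxicity, read by MTT assay, with a stated time of 72 h (on this read-out lower numbers stand for stronger inhibition and higher numbers for weaker inhibition), compound 3 `O=[N+]([O-])c1ccc(Nc2nc(SCc3ccc(C(F)(F)F)cc3)nc3ccccc23)cc1` gives 8170 nM. Compound 2 `FC(F)(F)c1ccc(CSc2nc(Nc3cccc(C(F)(F)F)c3)c3ccccc3n2)cc1` gives 15100 nM, and the step of a 1.8-fold lower number from compound 2 to compound 3 (0.27 log units; within the scatter) lies within the scatter, so the two cannot be ordered. Compound 1 `FC(F)(F)c1ccc(CSc2nc(Nc3ccccc3C(F)(F)F)c3ccccc3n2)cc1` reports only a limit, > 50000 nM, as noted in the limit of > 50000 nM in this assay, at which 1 of the 3 values shown sits. Against that limit, the steps of an at least 3.3-fold lower number from compound 1 to compound 2 (0.51 log units; beyond the scatter) and an at least 6.1-fold lower number from compound 1 to compound 3 (0.78 log units; beyond the scatter) show that the aryl group on the nitrogen can move the number by a modest margin. Compound 4 `COc1cc(Nc2nc(SCc3ccc(C(F)(F)F)cc3)nc3ccccc23)cc(OC)c1` differs from compound 3 by 3,5-dimethoxyphenyl in place of 4-nitrophenyl on a nitrogen on an aromatic ring. For the measured compounds named here, no measured step covers a 3,5-dimethoxyphenyl group; the measured steps only indicate that swapping this aryl group shifts the read-out modestly or not at all. The expected change is therefore small, a 1.2-fold higher number from compound 3 to compound 4 (0.09 log units; within the scatter), with no clear direction. Compound 4 is estimated at 10000 nM in this assay, with a range of 3000 nM to 40000 nM.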

Compound 4, half-maximal inhibitory concentration: 8580 nM
Compound 4: the middle estimate sits 1.2-fold (0.07 log units) above what was measured; low and high end bracket the measured number.
By their numbers in this assay, from the lowest: compounds 3, 4 and 2 (each within the scatter of the next). At a limit, above all of these: compound 1.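

In this assay, a ring carrying two methoxy groups on this nitrogen cannot be separated from the earlier aryl groups: a 1.1-fold higher number from compound 3 to compound 4 (0.02 log units; within the scatter) and a 1.8-fold lower number from compound 2 to compound 4 (0.25 log units; within the scatter) both lie within the scatter. Thus 4-nitrophenyl, 3-(trifluoromethyl)phenyl and 3,5-dimethoxyphenyl cannot be ordered, and among the compounds shown, only the 2-(trifluoromethyl)phenyl group of compound 1 stands apart. The one step here beyond the scatter, an at least 5.8-fold lower number from compound 1 to compound 4 (0.76 log units; beyond the scatter), is read against a limit rather than a number: the limit of > 50000 nM in this assay, at which 1 of the 4 values shown sits.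

Still open, as far as these compounds go, is whether an aryl ring bearing an amine or a carboxylic acid, or a cyclohexyl ring in place of the aryl group, would shift the number beyond the scatter. Also open, from the compounds shown here alone, is how the read-out responds to changes elsewhere on the shared core.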